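This account rests on a few compounds, and the source may have more. Where it says the series, first, only, none or still open, it means among the compounds named here.

Measured in a functional assay on the whole organism with Rattus norvegicus as the target; on this read-out higher numbers stand for an effect only at larger amounts of compound and lower numbers for an effect already at smaller amounts:
- compound 1 `CCCn1c(=N)sc2cc(OC(F)(F)F)ccc21`: 4.5 mg/kg
- compound 2 `CCN(CC)C(=O)Cn1c(=N)sc2cc(OC(F)(F)F)ccc21`: 9 mg/kg

Compound 2 stands within the scatter of compound 1. Among the measured compounds shown here, the single measured step, a 2.0-fold higher number from compound 1 to compound 2 (0.30 log units; within the scatter), has diethylcarbamoyl in place of ethyl at the same place. Compound 3 `CSCn1c(=N)sc2cc(OC(F)(F)F)ccc21` has methylsulfanyl in place of diethylcarbamoyl on a saturated chain carbon bound to an aromatic nitrogen. For the measured compounds named here, no measured compound carries methylsulfanyl, so the one step gives only weak guidance, and no change beyond the scatter is expected. The expected step is a 1.5-fold lower number from compound 2 to compound 3 (0.18 log units; within the scatter). For compound 3 the estimated value is 6 mg/kg, with an expected range of 2 mg/kg to 18 mg/kg.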

Compound 3, dose for half-maximal effect: 3 mg/kg
Beside the measured number, compound 3's estimate is 2.0-fold (0.30 log units) above it; measured number inside the range.
By their numbers in this assay, from the lowest: compounds 3, 1 and 2 (each within the scatter of the next, the first and the last beyond it).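

In this assay this place on a saturated chain carbon bound to an aromatic nitrogen now shows a step beyond the scatter, with methylsulfanyl in place of diethylcarbamoyl (a 3.0-fold lower number from compound 2 to compound 3 (0.48 log units; beyond the scatter)). Methylsulfanyl in place of ethyl stays within the scatter (a 1.5-fold lower number from compound 1 to compound 3 (0.18 log units; within the scatter)), so this read-out does not separate those two groups here. No supporting data bear on the reason for either step.

Open: whether an amine, a carboxylic acid or a longer chain at this place would keep the number near that of compound 3 or shift it.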